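The source may hold more compounds than are shown below. What is called first, only, known or untested is meant among the compounds shown, and "the series" means these compounds.

Compound 1, whose structure is `OC(c1ccc(Cl)cc1)(c1ccc(Br)cc1)c1cccnc1`, is the starting point here. In an ADME assay on L6 cells (Rattus norvegicus) for cytotoxicity, read by resazurin assay, with a stated time of 72 h (a lower number here means a stronger inhibitor, a higher number a weaker inhibitor), compound 1 gives 57000 nM, the only plain number among the two results shown. Compound 2, with the structure `CS(=O)(=O)Nc1ccc(C(O)(c2ccc(Cl)cc2)c2cccnc2)cc1`, returns only a limit of the assay in this assay, > 100000 nM. Going by the values given here, the one measured step, an at least 1.7-fold higher number from compound 1 to compound 2 (0.24 log units; that floor lies within the scatter), is a methanesulfonamido in place of bromo on an aromatic carbon, and its floor lies within the scatter, so it does not by itself show a real change; the evidence for that step is the limit of > 100000 nM in this assay, at which 1 of the 2 values shown sits.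

Compound 3, with the structure `OC(c1ccc(Cl)cc1)(c1cccnc1)c1cncs1`, is not yet measured. It differs from compound 1 by 1,3-thiazol-5-yl in place of 4-bromophenyl on a saturated chain carbon bound to two aromatic carbons and an oxygen on a saturated carbon. Among the compounds with values here, no measured step touches this exact exchange, and the only step available, from compound 1 to compound 2, points weakly toward a higher number. A small rise, possibly again reaching the limit, is therefore the expectation for compound 3, amounting to an expected 1.6-fold higher number from compound 1 to compound 3 (0.20 log units; within the scatter). The estimate for compound 3 in this assay is 90000 nM, expected to fall between 40000 nM and 200000 nM.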

Compound 3, half-maximal inhibitory concentration: > 100000 nM
Compound 3: a limit, no number; the forecaster's own chance of this, stated with the estimate: 40%; middle value at least 1.1-fold (0.04 log units) from the limit.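

In this assay compound 3 gives > 100000 nM, a limit of the assay and not a number. The step is an at least 1.7-fold higher number from compound 1 to compound 3 (0.24 log units; that floor lies within the scatter), so this floor alone does not establish a real change, but it does add something that the earlier pair could not show: there, only the bromo on the aromatic ring was exchanged, whereas here the whole 4-bromophenyl on the saturated chain carbon gives way to a 1,3-thiazol-5-yl, a five-membered aromatic ring with 2 hetero atoms. Two different exchanges that both remove the bromine therefore end at the same ceiling, which leaves the true size of either change hidden, and the readout at this position now rests mostly on: the limit of > 100000 nM in this assay, at which 2 of the 3 values shown sit.

Because both new values are limits, the compounds shown cannot tell how far either one lies beyond compound 1, or whether the two differ from each other. From the compounds shown here alone, it also remains open how this position would respond to a group such as an amine, a carboxylic acid or a longer chain, and whether any such group would give a plain number rather than another limit.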